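Swapping fluoro for methoxy in compound 3

A few compounds are considered here, and "the series" means these few. Any claim that something is new, unique, unknown or untested is made for them only; others in the source may bear on it.

In a functional assay on A2780 cells (Homo sapiens) for antiproliferative activity, read by resazurin assay, with a stated time of 72 h (on this read-out higher numbers stand for weaker inhibition and lower numbers for stronger inhibition), compound 3 `Cc1cccc(Cc2n[nH]c3cc(O)c(C(=O)N(C)Cc4ccc(F)cc4)cc23)c1` gives 590 nM and shares its range with two relatives: compound 1 `COc1ccc(CN(C)C(=O)c2cc3c(Cc4cccc(Cl)c4)n[nH]c3cc2O)cc1` at 390 nM and compound 2 `Cc1cccc(Cc2n[nH]c3cc(O)c(C(=O)N(C)Cc4ccccc4Br)cc23)c1` at 310 nM both lie within the scatter of it. Compound 4 `COc1ccc(CN(C)C(=O)c2cc3c(Cc4cccc(C)c4)n[nH]c3cc2O)cc1` has not been measured yet. It differs from compound 3 in one place, with methoxy in place of fluoro on an aromatic carbon, para to a large group (methoxy in place of fluoro on an aromatic carbon), so 4-fluorobenzyl becomes 4-methoxybenzyl. For the measured compounds named here, the one measured change of this group gives a 1.9-fold higher number from compound 2 to compound 3 (0.28 log units; within the scatter) with 4-fluorophenyl in place of 2-bromophenyl, and that step stays within the scatter. Compound 1 also carries 4-methoxybenzyl and gives 390 nM in this assay even though it differs from compound 4 elsewhere. No step beyond the scatter is therefore expected, and the estimate is a 1.4-fold lower number from compound 3 to compound 4 (0.15 log units; within the scatter) as a small expected move at most. For compound 4 the expected value is 420 nM with 200 nM to 850 nM as the estimated range.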

Compound 4, half-maximal inhibitory concentration: 540 nM
For compound 4 the middle estimate is 1.3-fold (0.11 log units) below the measured one; the measured number falls inside the stated range.
By their numbers in this assay, from the lowest: compounds 2, 1, 4 and 3 (each within the scatter of the next).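

In this assay, putting methoxy in place of fluoro on an aromatic carbon, para to a large group, gives a 1.1-fold lower number from compound 3 to compound 4 (0.04 log units; within the scatter) with the rest of the molecule held the same, so this swap can now be read directly and stays within the scatter. The neighbouring comparisons read the same way: methyl in place of chloro, with 4-methoxybenzyl kept, gives a 1.4-fold higher number from compound 1 to compound 4 (0.14 log units; within the scatter) and 4-methoxyphenyl in place of 2-bromophenyl gives a 1.7-fold higher number from compound 2 to compound 4 (0.24 log units; within the scatter) and neither step separates the compounds. Nothing available explains why these steps are so small.

The compounds shown leave open whether an amine or a carboxylic acid at this para position would move the number beyond the scatter. They also leave open whether a plain benzyl group, with hydrogen there, would behave like 4-fluorobenzyl and 4-methoxybenzyl.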